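The source may hold more compounds than are shown below. What is called first, only, known or untested is meant among the compounds shown, and "the series" means these compounds.

Compound 1 `CC1SC(c2cccc(C(=O)NCCCCc3ccccc3)c2)N(c2ccc(C3CC3)cc2)C1=O`: 1750 mL.min-1.g-1
Compound 2 `COc1ccccc1N1C(=O)C(C)SC1c1cccc(C(=O)NCCCCc2ccccc2)c1`: 1170 mL.min-1.g-1
Compound 3 `C#Cc1cccc(N2C(=O)CSC2c2cccc(C(=O)NCCCCc3ccccc3)c2)c1`: 973 mL.min-1.g-1

All three were measured in an ADME assay on microsomes from liver (Canis lupus familiaris) for metabolic stability, read by LC-MS, using NADPH, with a stated time of 10 min, tested at 0.1 uM; on this read-out higher numbers stand for fast clearance and lower numbers for slow clearance. Compound 3 sits at the low end of these numbers, yet its distances to compound 2 and to compound 1 both lie within the usual scatter, so the three cannot be told apart. Compound 4 `O=C(NCCCCc1ccccc1)c1cccc(C2SCC(=O)N2c2ccccc2F)c1` is not yet measured; it differs from compound 3 by 2-fluorophenyl in place of 3-ethynylphenyl on an amide-type nitrogen in a ring. Going by the values given here, no measured step swaps exactly these two groups. Among the compounds with values here, the one measured step, a 1.5-fold lower number from compound 1 to compound 2 (0.17 log units; within the scatter), also exchanges one aryl group for another on the same nitrogen and stays within the scatter. For compound 4 a step of a 1.0-fold higher number from compound 3 to compound 4 (0.01 log units; within the scatter) is therefore expected, nothing beyond the scatter. Compound 4 is expected to give 1000 mL.min-1.g-1, between 500 mL.min-1.g-1 and 2000 mL.min-1.g-1.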

Compound 4, intrinsic clearance in microsomes: 815 mL.min-1.g-1
Compound 4: middle estimate off by 1.2-fold (0.09 log units), on the high side; low and high end bracket the measured number.
By their numbers in this assay, from the lowest: compounds 4, 3, 2 and 1 (each within the scatter of the next, the first and the last beyond it).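

In this assay the exchange of 3-ethynylphenyl for 2-fluorophenyl gives a 1.2-fold lower number from compound 3 to compound 4 (0.08 log units; within the scatter), so the two compounds cannot be told apart. This is the second aryl swap on this amide-type nitrogen that stays within the scatter, and it holds on a core lacking the methyl group carried by compound 1 and compound 2. Nothing measured here explains the result. As far as these compounds go, whether a pyridine ring on this nitrogen, or an amine or carboxylic acid on its phenyl ring, would move the number beyond the scatter stays open. From the compounds shown here alone, the effect of that methyl group alone also stays open.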